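Moving the fluorine on the ring attached to the pyrrole nitrogen

A few compounds are considered here, and "the series" means these few. Any claim that something is new, unique, unknown or untested is made for them only; others in the source may bear on it.

Among the compounds with values here, compound 3, `Cc1c(CCOCCCO[N+](=O)[O-])cc(-c2ccc(S(C)(=O)=O)cc2)n1-c1cccc(F)c1`, is the only member of this small set for which an assay on J774 cells for inhibition of prostaglandin G/H synthase 1 (Mus musculus), read by immunoassay, with stated times of 15 min and 30 min (on this read-out higher numbers stand for weaker inhibition and lower numbers for stronger inhibition), yields an actual number: compound 3 gives 2900 nM. Compound 1, `Cc1c(CCOCCO[N+](=O)[O-])cc(-c2ccc(S(C)(=O)=O)cc2)n1-c1cccc(F)c1`, gives only a limit in this assay, > 10000 nM. Compound 2, `Cc1c(CCOCCCO[N+](=O)[O-])cc(-c2ccc(S(C)(=O)=O)cc2)n1-c1ccccc1`, likewise gives only a limit in this assay, > 10000 nM. The two measured steps therefore both end at compound 3: an at least 3.4-fold lower number from compound 1 to compound 3 (0.53 log units; beyond the scatter), and an at least 3.4-fold lower number from compound 2 to compound 3 (0.53 log units; beyond the scatter). Both rest on (the limit of > 10000 nM in this assay, at which 2 of the 3 values shown sit), so their true size is not known.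

Compound 4, `Cc1c(CCOCCCO[N+](=O)[O-])cc(-c2ccc(S(C)(=O)=O)cc2)n1-c1ccc(F)cc1`, differs from compound 3 by 4-fluorophenyl in place of 3-fluorophenyl on an aromatic nitrogen. Within the data shown here, the step from compound 2 to compound 3 shows that a fluoro on that ring can matter, but no measured step tells how a fluoro at a different position on it behaves, and the step from compound 1 to compound 3 concerns another part of the molecule. A step of modest size in either direction, or none beyond the scatter, is thus expected. This estimate means a step of a 1.4-fold higher number from compound 3 to compound 4 (0.14 log units; within the scatter), which is expected to stay near compound 3. Compound 4 is therefore estimated to give 4000 nM, with a range from 1500 nM to 12000 nM.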

Compound 4, half-maximal inhibitory concentration: > 10000 nM
Compound 4: only a limit was reported (the forecaster's own chance of this, stated with the estimate: 35%); middle value at least 2.5-fold (0.39 log units) away from the limit.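

In this assay, the position of the fluoro at this place on the aromatic nitrogen matters, and not only its presence: 4-fluorophenyl in place of 3-fluorophenyl gives an at least 3.4-fold higher number from compound 3 to compound 4 (0.53 log units; beyond the scatter). Among the compounds shown, the benefit of fluoro over hydrogen seen with 3-fluorophenyl therefore does not extend to every fluoro position, since 4-fluorophenyl also ends at the limit. The step from compound 2 to compound 4 cannot be read, and the true size of the step to compound 4 remains unknown: the limit of > 10000 nM in this assay, at which 3 of the 4 values shown sit.

Still open, going by these compounds, is how 2-fluorophenyl, or a chloro or methoxy group on the same ring, would behave at this place. On these data alone, it is also open whether the difference between 3-fluorophenyl and 4-fluorophenyl would hold with a longer chain in place of the 2-(3-(nitrooxy)propoxy)ethyl group.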